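Swapping a phenethyl for a dihydroindolyl on the core

This account rests on a few compounds, and the source may have more. Where it says the series, first, only, none or still open, it means among the compounds named here.

Measured so far:
- compound 1 `COc1ccc2[nH]c(C(=O)N3CC(=O)N(Cc4ccccc4)[C@@H](CCc4ccccc4)C3)cc2c1`: > 30000 nM
- compound 2 `COc1ccc2[nH]c(C(=O)N3CC(=O)N(c4ccccc4)[C@@H](Cc4ccccc4)C3)cc2c1`: > 30000 nM
- compound 3 `COc1cccc(CN2C(=O)CN(C(=O)c3cc4cc(OC)ccc4[nH]3)C[C@@H]2CCc2ccccc2)c1`: 4500 nM

In an ADME assay on Vero cells (Chlorocebus sabaeus) for cytotoxicity, with a stated time of 7 days (a lower number here means that less compound is tolerated, a higher number that more compound is tolerated), compound 1 gives > 30000 nM, which is a limit of the assay and not a number. Compound 2 likewise sits at a limit, > 30000 nM. Compound 3 is the only one of the three with a measured number, 4500 nM. Among the measured compounds shown here, the single step between neighbours, an at least 6.6-fold lower number from compound 1 to compound 3 (0.82 log units; beyond the scatter), shows that a small change on the shared core can carry a compound from the limit to a measured value; this is the only evidence available, and it concerns the position noted in the limit of > 30000 nM in this assay, at which 2 of the 3 values shown sit.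

Compound 4 `COc1ccc2[nH]c(C(=O)N3CC(=O)N(Cc4ccccc4)[C@@H](N4CCc5ccccc54)C3)cc2c1` differs from compound 1 in one place: 2,3-dihydro-1H-indol-1-yl in place of phenethyl on a saturated ring carbon. For the measured compounds named here, no measured step touches this part of the core, so the change from compound 1 to compound 3 offers no direct guide and the expectation rests on compound 1 alone. With compound 1 at the limit, compound 4 is expected to remain there too, with no step beyond the scatter, so that a number no higher from compound 1 to compound 4 (the limit leaves the size open) is the estimated outcome. Compound 4 is accordingly estimated at 30000 nM, in the range from 12000 nM to 80000 nM.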

Compound 4, half-maximal cytotoxic concentration: > 100000 nM
Compound 4: a limit, no number (the forecaster's own chance of this, stated with the estimate: 60%); at least 3.3-fold (0.52 log units) between middle value and limit.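

In this assay compound 4 gives > 100000 nM, which is a limit and not a number. Compound 1 gives > 30000 nM, also a limit, and the step between compound 1 and compound 4 cannot be read. The compounds shown leave open whether 2,3-dihydro-1H-indol-1-yl in place of phenethyl on a saturated ring carbon changes the tolerated concentration at all.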